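Sulfonamide aryl replacement in the quinoline-ether series

The source may hold more compounds than are shown below. What is called first, only, known or untested is meant among the compounds shown, and "the series" means these compounds.

Two compounds of this series have numbers in a functional assay on HCC827 cells (Homo sapiens) for cytotoxicity, read by MTT assay, with a stated time of 48 h; on this read-out higher numbers stand for weaker inhibition and lower numbers for stronger inhibition. Compound 1 `COc1cc2c(Oc3ccc(NS(=O)(=O)c4cccc(-c5ccsc5)c4)cc3F)ccnc2cc1OCCCN1CCN(C)CC1` gives 1940 nM in this assay. Compound 2 `COc1cc2c(Oc3ccc(NS(=O)(=O)c4cc(-c5ccsc5)ccc4F)cc3F)ccnc2cc1OCCCN1CCN(C)CC1` carries a fluoro in place of a hydrogen on an aromatic carbon and gives 2820 nM in this assay; the step of a 1.5-fold higher number from compound 1 to compound 2 (0.16 log units; within the scatter). Compound 2 therefore has the highest of the two numbers, with compound 1 nearest, and the two lie within the scatter of each other, so no order between them can be read.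

Compound 3 `COc1cc2c(Oc3ccc(NS(=O)(=O)c4cccc(-c5ccco5)c4)cc3F)ccnc2cc1OCCCN1CCN(C)CC1` is not yet measured in this assay. It differs from compound 2 in 3-(furan-2-yl)phenyl in place of 2-fluoro-5-(thiophen-3-yl)phenyl on a sulfonyl sulfur. Going by the values given here, of the measured steps only the one from compound 1 to compound 2 bears on this change, and only on the fluoro part of it; it was within the scatter. Among the compounds with values here, for the exchange of the thiophen-3-yl for a furan-2-yl no measured step exists. Within the data shown here, with the single relevant step within the scatter, no step beyond the scatter is expected in this assay, in either direction, which means an expected step of a 1.4-fold lower number from compound 2 to compound 3 (0.15 log units; within the scatter). Compound 3 is estimated at 2000 nM in this assay, in a range from 700 nM to 5500 nM.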

Compound 3, half-maximal inhibitory concentration: 3110 nM
The estimate for compound 3 lay 1.6-fold (0.19 log units) below the measured number; the measured number falls inside the stated range.
By their numbers in this assay, from the lowest: compounds 1, 2 and 3 (each within the scatter of the next).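

In this assay, 3-(furan-2-yl)phenyl in place of 2-fluoro-5-(thiophen-3-yl)phenyl on a sulfonyl sulfur gives a 1.1-fold higher number from compound 2 to compound 3 (0.04 log units; within the scatter), and furan-2-yl in place of thiophen-3-yl on an aromatic carbon, without the fluoro as part of the change, gives a 1.6-fold higher number from compound 1 to compound 3 (0.20 log units; within the scatter). Both steps lie within the scatter, so the exchange of the five-membered aromatic ring, which the step between compound 1 and compound 2 did not touch, has no readable effect in this assay, and no order can be read among compound 1, compound 2 and compound 3. Nothing available bears on why these numbers stay together.

From the compounds shown here alone, it remains open whether this position would keep the same numbers with a group other than a five-membered aromatic ring with one hetero atom, such as a pyridine, a morpholine or a carboxylic acid in place of the furan-2-yl. Going by these compounds, whether the fluoro and the furan-2-yl would together give a step beyond the scatter on a single compound also remains open.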